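Swapping Fluoro for Methyl on the Aromatic Ring

A few compounds are considered here, and "the series" means these few. Any claim that something is new, unique, unknown or untested is made for them only; others in the source may bear on it.

Compound 1 `CCC(C(=O)N1CCN(c2cccc(F)c2)CC1)N1C(=O)CCC1=O` is the weaker of the two measured compounds: in a functional assay on the whole organism (strain Swiss) with Mus musculus as the target, in the maximal electroshock model, with a stated time of 2 h, at a dose of 300 mg/kg by the intraperitoneal route (a lower number here means a weaker effect, a higher number a stronger effect of the compound at the dose given), compound 1 gives 0%, while compound 2 `CC(C(=O)N1CCN(c2cccc(F)c2)CC1)N1C(=O)CCC1=O` gives 100%. Among the measured compounds shown here, the only measured step, a number 100 percentage points higher from compound 1 to compound 2 (beyond the scatter), alters the saturated chain and not the aromatic ring, so it does not bear on the change considered here. Compound 3 `CCC(C(=O)N1CCN(c2cccc(C)c2)CC1)N1C(=O)CCC1=O` differs from compound 1 by methyl in place of fluoro on an aromatic carbon. Without a measured step on this change, and with compound 1 at the bottom, only a small upward move is expected, a number 15 percentage points higher from compound 1 to compound 3 (beyond the scatter). Compound 3 is therefore estimated at 15%, within 0% to 50%.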

Compound 3, a percentage reported as activity, at one dose (the size of the read-out at that dose, not a potency): 0%
Compound 3: the middle estimate sits 15 percentage points above what was measured; measured number inside the range.
By their numbers in this assay, from the lowest: compounds 1 and 3 (each within the scatter of the next); then compound 2.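

In this assay the swap from 3-fluorophenyl to 3-methylphenyl gives no change at the digits printed from compound 1 to compound 3 (within the scatter) and so, on this core, neither group at this ring carbon gives any effect at the dose used. With compound 1 at 0% this step could show only a gain, and none appeared. Nothing available explains this result.

Going by these compounds, whether methyl behaves the same on the core of compound 2 at 100% where a loss could show, stays open. So does the outcome with methoxy, chlorine or an amine at this ring carbon.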